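The source may report more compounds than this note shows. Statements on the series, on what has been measured and on what is new or still open speak of the compounds shown alone.

Three compounds of the series have numbers in a functional assay on MGC-803 cells (Homo sapiens) for antiproliferative activity, read by CCK-8 assay, with a stated time of 72 h, tested at 2 uM; on this read-out higher numbers stand for a stronger effect at the one concentration tested and lower numbers for a weaker effect. Compound 1 `CN(Cc1ccncc1)C(=S)SCc1ccc(C(=O)Nc2ccccc2N)cc1` gives 38.1%. Compound 2 `Nc1ccccc1NC(=O)c1ccc(CSC(=S)N2CCN(c3ccncc3)CC2)cc1` gives 64.8%. Compound 3 `Nc1ccccc1NC(=O)c1ccc(CSC(=S)N(Cc2ccccc2)Cc2ccccc2)cc1` gives 11%. Compound 2 stands highest of the three in this assay, with compound 1 lower by a margin beyond the scatter and compound 3 lower still, also beyond the scatter, so compound 2 is the most active of the measured set. Compound 4 `N#Cc1ccc(N2CCN(C(=S)SCc3ccc(C(=O)Nc4ccccc4N)cc3)CC2)cc1` is not yet measured. It differs from compound 2 in one place: 4-cyanophenyl in place of pyridin-4-yl on an amine nitrogen in a ring. The rest of the shared core is unchanged. Within the data shown here, no measured pair separates pyridin-4-yl from 4-cyanophenyl on an amine nitrogen in a ring, so nothing in the numbers fixes the size of this step. Given that compound 2 shows 64.8% and the other two compounds sit far below it, a small downward step is expected, of a size that may stay within the scatter. The expected step of a number 9.8 percentage points lower from compound 2 to compound 4 (within the scatter) is estimated to be modest. Compound 4 is estimated at 55%, with a range from 35% to 72% in this assay.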

Compound 4, a percentage reported as inhibition, at one concentration (the size of the read-out at that concentration, not a potency): 34.5%
Compound 4: the middle estimate sits 20.5 percentage points above what was measured; the measured number lies below the stated range.
By their numbers in this assay, from the lowest: compound 3; then compounds 4 and 1 (each within the scatter of the next); then compound 2.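

In this assay, the group on the amine nitrogen in a ring is a position that moves the read-out: 4-cyanophenyl in place of pyridin-4-yl gives a number 30.3 percentage points lower from compound 2 to compound 4 (beyond the scatter), a large step. Among these compounds, the earlier compounds held no pair differing in one place, so this is the first single change whose size can be read, and here pyridin-4-yl is the better of the two groups. No measurement on hand accounts for the size of this step.

The change swaps the ring and adds the nitrile in one move, and the compounds shown do not separate these two parts. Going by these compounds, a plain phenyl on the same nitrogen would separate them, and it remains open whether pyridin-3-yl there would hold the level of compound 2.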